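This account rests on a few compounds, and the source may have more. Where it says the series, first, only, none or still open, it means among the compounds named here.

Measured in a functional assay on HeLa cells (Homo sapiens) for antiproliferative activity, read by MTT assay, with a stated time of 24 h (on this read-out higher numbers stand for weaker inhibition and lower numbers for stronger inhibition), so far:

Compound 1 `COc1ccc(S(=O)(=O)n2c(-c3cn(-c4ccccc4)nc3-c3ccc(F)cc3)nc3ccccc32)cc1` gives 390 nM
Compound 2 `O=[N+]([O-])c1ccc(S(=O)(=O)n2c(-c3cn(-c4ccccc4)nc3-c3ccc(F)cc3)nc3ccccc32)cc1` gives 1170 nM
Compound 3 `O=S(=O)(c1ccc(Cl)cc1)n1c(-c2cn(-c3ccccc3)nc2-c2ccc(F)cc2)nc2ccccc21` gives 3450 nM

Compound 3 has the highest number of the three and is therefore the weakest inhibitor among them in this assay here. The next compound to consider is compound 4 `O=S(=O)(c1ccc(Br)cc1)n1c(-c2cn(-c3ccccc3)nc2-c2ccc(F)cc2)nc2ccccc21` with bromo in place of chloro on an aromatic carbon, para to a large group. The whole change is bromo in place of chloro on an aromatic carbon and nothing else in the molecule differs.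

Among the measured compounds shown here, no measured step replaces chloro with bromo, so the evidence is indirect. Three steps changed the group at this same place: a 3.0-fold higher number from compound 1 to compound 2 (0.48 log units; beyond the scatter) and a 2.9-fold higher number from compound 2 to compound 3 (0.47 log units; beyond the scatter) and an 8.8-fold higher number from compound 1 to compound 3 (0.95 log units; beyond the scatter) and all of them were modest but beyond the usual scatter. Each of those steps involved methoxy or nitro, whereas this one only exchanges chloro for bromo, so a smaller step with no clear direction is expected. The estimate is a 1.2-fold lower number from compound 3 to compound 4 (0.09 log units; within the scatter) and this expected step is unlikely to stand out from the scatter. In this assay compound 4 is estimated at 2800 nM with an expected range of 1000 nM to 7000 nM around that figure.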

Compound 4, half-maximal inhibitory concentration: 2040 nM
The estimate for compound 4 lay 1.4-fold (0.14 log units) above the measured number; the measured number falls inside the stated range.
By their numbers in this assay, from the lowest: compound 1; then compounds 2, 4 and 3 (each within the scatter of the next, the first and the last beyond it).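

In this assay, exchanging one halogen for the other at this ring position gives a 1.7-fold lower number from compound 3 to compound 4 (0.23 log units; within the scatter), so chloro and bromo cannot be told apart here. The comparison with nitro, a 1.7-fold higher number from compound 2 to compound 4 (0.24 log units; within the scatter), also stays within the scatter, which places the bromo compound close to both of its neighbours in the ranking, even though the nitro and chloro compounds are separated by a step beyond the scatter. The remaining comparison, a 5.2-fold higher number from compound 1 to compound 4 (0.72 log units; beyond the scatter), lies beyond the scatter and leaves compound 1, with its methoxy group, as the strongest inhibitor of the four, but nothing available explains this difference.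

From the compounds shown here alone, whether this advantage belongs to methoxy alone or extends to related groups such as ethoxy, hydroxyl or an amine at the same place remains open, as does where a methyl group or a carboxylic acid would fall relative to the halogens and nitro. Going by these compounds, all four compounds also carry their varied group at this one place on the ring, so the effect of moving it elsewhere on that ring is unknown.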